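Cyclobutyl Amide in Place of an Oxazole Amide

The source may report more compounds than this note shows. Statements on the series, on what has been measured and on what is new or still open speak of the compounds shown alone.

Measured so far:
compound 1 `CCn1c(-c2ccc(C(F)(F)F)nc2)nc2c(O[C@H]3CCN(C(=O)c4cocn4)C3)ncnc21`: 1.2 L/kg
compound 2 `CCn1c(-c2cnc(C)nc2)nc2c(O[C@H]3CCN(C(=O)C4CCC4)C3)ncnc21`: 1 L/kg

Among the compounds with values here, in an ADME assay (Canis lupus familiaris, strain Beagle) for pharmacokinetics (a lower number here means that more of the compound stays in the plasma, a higher number that more of the compound sits outside the plasma), compound 1 gives 1.2 L/kg, the higher of the two numbers measured so far, while compound 2 gives 1 L/kg. These two values lie within the usual scatter of each other, so no order between them can be claimed. Within the data shown here, no step between measured compounds that differ in only one place is available, so there is no single-change precedent to lean on.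

Compound 3 `CCn1c(-c2ccc(C(F)(F)F)nc2)nc2c(O[C@H]3CCN(C(=O)[C@H]4C[C@@H](OC)C4)C3)ncnc21` has not yet been tested in this assay. It differs from compound 1 in one place: 3-methoxycyclobutyl in place of 1,3-oxazol-4-yl on a carbonyl carbon. The two measured compounds carry different groups at this same carbonyl carbon and on the core, yet their values sit close together, which suggests the number is not very sensitive to what sits on the carbonyl carbon.

The step of a 1.1-fold higher number from compound 1 to compound 3 (0.03 log units; within the scatter) is expected to be small, within the scatter, and if anything slightly upward, because compound 1 gives 1.2 L/kg and compound 2 gives 1 L/kg. For compound 3 the estimate in this assay is 1.3 L/kg, with a range from 0.7 L/kg to 2.4 L/kg.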

Compound 3, volume of distribution: 1.1 L/kg
For compound 3 the middle estimate is 1.2-fold (0.07 log units) above the measured one; the range from low to high includes it.
By their numbers in this assay, from the lowest: compounds 2, 3 and 1 (each within the scatter of the next).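

Within the data shown here, this is the first comparison where only one place changes, with the core of compound 1 kept, and in this assay the swap at the carbonyl carbon lies within the scatter (a 1.1-fold lower number from compound 1 to compound 3 (0.04 log units; within the scatter)). The groups involved are quite different: 1,3-oxazol-4-yl is a five-membered aromatic ring with 2 hetero atoms, while 3-methoxycyclobutyl is a four-membered non-aromatic ring of carbon only, with 2 defined stereocentres, yet compound 1 and compound 3 cannot be told apart on volume of distribution. For this pair, then, replacing an aromatic ring on the amide carbonyl with a non-aromatic one leaves no measurable mark on the read-out, although nothing shown explains why the two compounds read alike.

As far as these compounds go, a single pair cannot show whether this position is insensitive in general, so it remains open whether a group of another kind on the carbonyl carbon, such as an amine or a carboxylic acid, would also stay within the scatter. From the compounds shown here alone, it is also open whether the other stereoisomer of the 3-methoxycyclobutyl group would read the same.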